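Swapping Bromine for Iodine on a Nucleotide Agonist

This account rests on a few compounds, and the source may have more. Where it says the series, first, only, none or still open, it means among the compounds named here.

Of the compounds shown here, three built on one shared core have been tested in a functional assay on 1321-N1 cells for agonist activity at P2Y purinoceptor 4 (Homo sapiens), read by scintillation counting and inositol phosphate accumulation; a higher number here means that more compound is needed for the effect, a lower number that less compound is needed. Compound 1 `O=C(O)CCCO/N=c1/ccn([C@@H]2O[C@H](COP(=O)(O)OP(=O)(O)OP(=O)(O)O)[C@@H](O)[C@H]2O)c(=O)[nH]1` gives 470 nM. Compound 2 `O=c1[nH]/c(=N\OCCOc2ccccc2)ccn1[C@@H]1O[C@H](COP(=O)(O)OP(=O)(O)OP(=O)(O)O)[C@@H](O)[C@H]1O` gives 430 nM, and the step of a 1.1-fold lower number from compound 1 to compound 2 (0.04 log units; within the scatter) lies within the scatter. Compound 3 `O=c1[nH]/c(=N\OCCCc2ccc(Br)cc2)ccn1[C@@H]1O[C@H](COP(=O)(O)OP(=O)(O)OP(=O)(O)O)[C@@H](O)[C@H]1O` gives 141 nM, the lowest of the three numbers; the steps of a 3.3-fold lower number from compound 1 to compound 3 (0.52 log units; beyond the scatter) and a 3.0-fold lower number from compound 2 to compound 3 (0.48 log units; beyond the scatter) both lie beyond the scatter, so compound 3 stands apart from the other two.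

Compound 4 `O=c1[nH]/c(=N\OCCCc2ccc(I)cc2)ccn1[C@@H]1O[C@H](COP(=O)(O)OP(=O)(O)OP(=O)(O)O)[C@@H](O)[C@H]1O` differs from compound 3 in one place: iodo in place of bromo on an aromatic carbon. Neither measured step touches a halogen exchange; both that reach compound 3 describe replacing a carboxy or a phenoxy end group with the 4-bromobenzyl chain, and they were modest. Within the data shown here, nothing among the measured compounds shows what exchanging one halogen for another does on this chain end, so the expected step in this assay is small, with no clear direction, and likely within the scatter.

The estimate for compound 4 in this assay is therefore 120 nM, expected to fall between 50 nM and 300 nM, which corresponds to an expected step of a 1.2-fold lower number from compound 3 to compound 4 (0.07 log units; within the scatter).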

Compound 4, half-maximal effective concentration: 91 nM
For compound 4 the middle estimate is 1.3-fold (0.12 log units) above the measured one, and the stated range covers the measured number.
By their numbers in this assay, from the lowest: compounds 4 and 3 (each within the scatter of the next); then compounds 2 and 1 (each within the scatter of the next).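

In this assay, iodo in place of bromo gives a 1.5-fold lower number from compound 3 to compound 4 (0.19 log units; within the scatter), so on this aromatic carbon, para to a large group, one halogen can take the place of the other with no change that can be told from the scatter. Compound 4 also keeps the separation from the two compounds without a halogen, with a 4.7-fold lower number from compound 2 to compound 4 (0.67 log units; beyond the scatter) and a 5.2-fold lower number from compound 1 to compound 4 (0.71 log units; beyond the scatter), so that compounds 3 and 4 together form a pair apart from compounds 1 and 2, as compound 3 alone could not show. No measurement at hand explains why the two halogen-bearing chain ends give the lower numbers.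

The compounds shown leave open whether chloro or fluoro on this same carbon, or a plain phenyl with no halogen at all, would hold the number as low as bromo and iodo do. They also leave open how a shorter or longer chain leading to the 4-iodophenyl would fare, and whether an amine or a carboxylic acid could stand in place of the halogen.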